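The source may hold more compounds than are shown below. What is called first, only, known or untested is meant among the compounds shown, and "the series" means these compounds.

Compound 1 `COc1ccc(C(=O)N(O)C(C)c2ccc3oc(-c4ccccc4)cc3c2)cc1OC`: 200 nM
Compound 2 `CC(c1ccc2oc(-c3ccccc3)cc2c1)N(O)C(=O)c1ccco1`: 40 nM

In an assay on RBL cells for inhibition of Polyunsaturated fatty acid 5-lipoxygenase (Rattus norvegicus) (on this read-out higher numbers stand for weaker inhibition and lower numbers for stronger inhibition), compound 2 holds the lowest of the two numbers; the nearest is compound 1 with 200 nM, and the step of a 5.0-fold lower number from compound 1 to compound 2 (0.70 log units; beyond the scatter) lies beyond the scatter. Compound 3 `CC(c1ccc2oc(-c3ccccc3)cc2c1)N(O)C(=O)c1cccs1` differs from compound 2 in one place: thiophen-2-yl in place of furan-2-yl on a carbonyl carbon. No measured step concerns this exchange; the only step shown, a 5.0-fold lower number from compound 1 to compound 2 (0.70 log units; beyond the scatter), replaces a different group at the same carbonyl carbon and does not bear on it. With no comparison to lean on, compound 3 is expected to give a step of a 1.3-fold lower number from compound 2 to compound 3 (0.12 log units; within the scatter) that stays within the scatter. Compound 3 is estimated at 30 nM, with a range from 10 nM to 100 nM.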

Compound 3, half-maximal inhibitory concentration: 250 nM
For compound 3 the middle estimate is 8.3-fold (0.92 log units) below the measured one; the whole stated range lies below it.
By their numbers in this assay, from the lowest: compound 2; then compounds 1 and 3 (each within the scatter of the next).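

In this assay the step of a 6.3-fold higher number from compound 2 to compound 3 (0.80 log units; beyond the scatter) shows that this carbonyl position separates furan-2-yl from thiophen-2-yl, although both are five-membered aromatic rings with the same heavy-atom count. The step of a 1.3-fold higher number from compound 1 to compound 3 (0.10 log units; within the scatter) stays within the scatter, so thiophen-2-yl cannot be told apart from 3,4-dimethoxyphenyl here, and among these three groups only furan-2-yl stands out. Nothing available explains the difference between the oxygen and sulfur rings.

Open, from the compounds shown here alone, is how other groups on this carbonyl carbon, such as pyridin-2-yl or methyl, would compare with furan-2-yl. Also open, going by these compounds, is whether the furan-2-yl result holds on a different core.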